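Removing the Trifluoromethyl Group from Compound 3

The source may hold more compounds than are shown below. What is called first, only, known or untested is meant among the compounds shown, and "the series" means these compounds.

Measured compounds:
compound 1 `Fc1cccc(NC(=S)N/N=C/c2ccc3ccccc3n2)c1`, 74700 nM
compound 2 `S=C(N/N=C/c1ccc2ccccc2n1)Nc1cccc(Br)c1`, 58900 nM
compound 3 `FC(F)(F)c1ccccc1NC(=S)N/N=C/c1ccc2ccccc2n1`, 18100 nM

In a functional assay on HT-29 cells (Homo sapiens) for antiproliferative activity, read by sulforhodamine B assay, with a stated time of 72 h (a lower number here means a stronger inhibitor, a higher number a weaker inhibitor), compound 3 stands lowest of the three numbers; compound 2 lies beyond the scatter above it, and compound 1 further still. For the measured compounds named here, the step from compound 1 to compound 2 is a 1.3-fold lower number from compound 1 to compound 2 (0.10 log units; within the scatter), the only step between two measured compounds that differ in one place, and it concerns an exchange of one halogen for another.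

Compound 4 `S=C(N/N=C/c1ccc2ccccc2n1)Nc1ccccc1` differs from compound 3 in this way: hydrogen in place of trifluoromethyl on an aromatic carbon. Going by the values given here, no measured step covers this exchange: the halogen swap in the step from compound 1 to compound 2 says nothing about taking a group away entirely. What is known is that compound 3, which carries the trifluoromethyl, gives the lowest number of the three, while compound 1 and compound 2, which carry a single halogen in its place, give higher numbers. Compound 4 is therefore expected to give a higher number than compound 3, with the step estimated as a 2.5-fold higher number from compound 3 to compound 4 (0.40 log units; beyond the scatter). The value of compound 4 in this assay is estimated at 45000 nM, within a range of 15000 nM to 120000 nM.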

Compound 4, half-maximal inhibitory concentration: 17000 nM
Estimate against measurement, compound 4: 2.6-fold (0.42 log units) above; the measured number falls inside the stated range.
By their numbers in this assay, from the lowest: compounds 4 and 3 (each within the scatter of the next); then compounds 2 and 1 (each within the scatter of the next).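

In this assay hydrogen does as well as trifluoromethyl on this aromatic carbon, with a 1.1-fold lower number from compound 3 to compound 4 (0.03 log units; within the scatter) so the low number of compound 3 does not depend on that group. The bare ring also gives lower numbers than the two halogen compounds, with a 3.5-fold lower number from compound 2 to compound 4 (0.54 log units; beyond the scatter) and a 4.4-fold lower number from compound 1 to compound 4 (0.64 log units; beyond the scatter) so it is the bromo and fluoro compounds that stand apart, not the trifluoromethyl compound. No measurement shown explains why these numbers fall as they do.

As far as these compounds go, it remains open whether any other group on this carbon, such as an amine, a carboxylic acid or a longer chain, would move the number away from that of compound 4. From the compounds shown here alone, it also remains open whether a number much lower than these can be reached by changing this ring at all.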